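The source may report more compounds than this note shows. Statements on the series, on what has been measured and on what is new or still open speak of the compounds shown alone.

The measured compounds:
compound 1 `Cc1n[nH]cc1-c1cccc2c1CCC2c1ncc[nH]1` gives 3 nM in a functional assay on CHO cells for agonist activity at Alpha-1A adrenergic receptor (Homo sapiens), read by FLIPR and calcium flux; on this read-out higher numbers stand for an effect only at larger amounts of compound and lower numbers for an effect already at smaller amounts
compound 2 `c1ccc(-c2cccc3c2CCC3c2ncc[nH]2)nc1` gives 1150 nM in this assay
compound 3 `CS(=O)(=O)Nc1cccc2c1CCC2c1ncc[nH]1` gives 70 nM in this assay

Compound 2 stands at the highest number of the three: compound 3 is nearest, through a 16-fold lower number from compound 2 to compound 3 (1.22 log units; beyond the scatter), and compound 1 is furthest, through a 380-fold higher number from compound 1 to compound 2 (2.58 log units; beyond the scatter).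

Compound 4 `Cn1cc(-c2cccc3c2CCC3c2ncc[nH]2)cn1` has not yet been measured. It differs from compound 2 in one place: 1-methyl-1H-pyrazol-4-yl in place of pyridin-2-yl on an aromatic carbon.

The step that bears most directly on this change is a 380-fold higher number from compound 1 to compound 2 (2.58 log units; beyond the scatter). The group leaving in that step, 3-methyl-1H-pyrazol-4-yl, is a close relative of the 1-methyl-1H-pyrazol-4-yl entering here; the change from compound 2 to compound 4 therefore runs much of that step in reverse, with the methyl moved onto a ring nitrogen and the hydrogen-bond donor gone. The step of a 16-fold lower number from compound 2 to compound 3 (1.22 log units; beyond the scatter) adds that another group in this position also gave a far lower number than pyridin-2-yl. A large step downwards in this assay is therefore expected, though perhaps not all the way back to compound 1. Compound 4 is estimated at 15 nM, with a range from 3 nM to 80 nM, which is expected to mean a 77-fold lower number from compound 2 to compound 4 (1.88 log units; beyond the scatter).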

Compound 4, half-maximal effective concentration: > 2900 nM
Compound 4: no number, only a limit; the forecaster's own chance of this, stated with the estimate: 2%; middle value at least 190-fold (2.28 log units) from the limit.
By their numbers in this assay, from the lowest: compound 1; then compound 3; then compound 2. At a limit, above all of these: compound 4.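

Compound 4 carries no number in this assay, only a limit: the limit of > 2900 nM in this assay, at which 1 of the 4 values shown sits.
Even so, a methyl-bearing pyrazole ring does not by itself bring the low number of compound 1: 1-methyl-1H-pyrazol-4-yl in place of 3-methyl-1H-pyrazol-4-yl gives an at least 960-fold higher number from compound 1 to compound 4 (2.98 log units; beyond the scatter), so this position separates two closely related groups sharply. The same group gives no gain over pyridin-2-yl, with an at least 2.5-fold higher number from compound 2 to compound 4 (0.40 log units; beyond the scatter), and it also falls short of methanesulfonamido, with an at least 41-fold higher number from compound 3 to compound 4 (1.61 log units; beyond the scatter).

The two pyrazolyl groups differ in both where the methyl sits and which ring nitrogen carries it, so these compounds cannot show which of these matters. On these data alone, a plain 1H-pyrazol-4-yl group without any methyl would help to separate the two, and how far compound 4 really lies from compound 2 stays open behind the limit.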